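This account rests on a few compounds, and the source may have more. Where it says the series, first, only, none or still open, it means among the compounds named here.

Measured so far:
Compound 1, `O=C(N/N=C/c1ccc(Br)cc1)N1CCc2ncnc(Nc3ccc(F)c(Cl)c3)c2C1`. In a functional assay on NCI-H1975 cells (Homo sapiens) for cytotoxicity, read by MTT assay, with a stated time of 72 h (a lower number here means a stronger inhibitor, a higher number a weaker inhibitor), compound 1 reaches only the assay limit, > 200000 nM.
Compound 2, `Cc1ccc(/C=N/NC(=O)N2CCc3ncnc(Nc4ccc(F)c(Cl)c4)c3C2)cc1C`. In this assay compound 2 gives 6830 nM.

Going by the values given here, compound 2 therefore holds the only number in this set; the other entry is a limit (the limit of > 200000 nM in this assay, at which 1 of the 2 values shown sits). Among the compounds with values here, the single measured step, an at least 29-fold lower number from compound 1 to compound 2 (1.46 log units; beyond the scatter), was large, and it shows that the group on the carbon with a double bond to nitrogen can move the outcome strongly. Compound 3, `O=C(N/N=C/c1cccs1)N1CCc2ncnc(Nc3ccc(F)c(Cl)c3)c2C1`, differs from compound 2 by thiophen-2-yl in place of 3,4-dimethylphenyl on a carbon with a double bond to nitrogen. Within the data shown here, no measured step covers this particular exchange; the step already seen only indicates that a swing of that size is possible at the carbon with a double bond to nitrogen. A change in either direction seems plausible, and a moderate weakening is expected, a 2.9-fold higher number from compound 2 to compound 3 (0.47 log units; beyond the scatter). Compound 3 is thus estimated at 20000 nM, with a range from 5000 nM to 100000 nM.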

Compound 3, half-maximal inhibitory concentration: 33000 nM
Compound 3: middle estimate off by 1.7-fold (0.22 log units), on the low side; low and high end bracket the measured number.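

In this assay, the place on a carbon with a double bond to nitrogen now carries a five-membered aromatic ring with a hetero atom and still gives a measurable number, so a six-membered aromatic ring of carbon only is not required there. Thiophen-2-yl lies between the two earlier groups: the exchange from 3,4-dimethylphenyl gives a 4.8-fold higher number from compound 2 to compound 3 (0.68 log units; beyond the scatter), while the exchange from 4-bromophenyl gives an at least 6.0-fold lower number from compound 1 to compound 3 (0.78 log units; beyond the scatter). Compound 1 stands only at a limit, so that second step is a bound and not a measured size: the limit of > 200000 nM in this assay, at which 1 of the 3 values shown sits.

The compounds shown do not separate the effect of ring type from that of the groups on the ring, which unsubstituted phenyl would address. They also leave open how a saturated ring such as cyclohexyl, or a phenyl ring carrying an amine or a carboxylic acid, would behave here.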